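Hexyloxy in place of benzyloxy on the shared core

The source may hold more compounds than are shown below. What is called first, only, known or untested is meant among the compounds shown, and "the series" means these compounds.

Compound 1 `CN(C)CCNc1ccnc2cc(OCc3ccccc3)ccc12` gives 2140 nM in a functional assay on DLD-1 cells (Homo sapiens) for cytotoxicity, read by MTT assay, with a stated time of 48 h (a lower number here means a stronger inhibitor, a higher number a weaker inhibitor), level with compound 3 `Clc1ccnc2cc(OCCCc3ccccc3)ccc12` at 2140 nM, and together these two are the lowest of the three numbers. Compound 2 `Clc1ccnc2cc(OCc3ccccc3)ccc12` gives 3270 nM; the step of a 1.5-fold higher number from compound 1 to compound 2 (0.18 log units; within the scatter) stays within the scatter. Compound 4 `CCCCCCOc1ccc2c(NCCN(C)C)ccnc2c1` differs from compound 1 by pentyl in place of phenyl on a saturated chain carbon bound to an oxygen on an aromatic ring. Among the compounds with values here, no measured step alters this very group; the nearest comparison is compound 2 against compound 3, whose values stand close together. The change from compound 1 to compound 4 is therefore expected to move this assay little, in neither direction beyond the scatter. Compound 4 is estimated at 2500 nM, with a range from 1000 nM to 6500 nM. This is expected to mean a step of a 1.2-fold higher number from compound 1 to compound 4 (0.07 log units; within the scatter).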

Compound 4, half-maximal inhibitory concentration: 1870 nM
For compound 4 the middle estimate is 1.3-fold (0.13 log units) above the measured one; the range from low to high includes it.
By their numbers in this assay, from the lowest: compounds 4, 1, 3 and 2 (each within the scatter of the next).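

Putting hexyloxy in place of benzyloxy gives, in this assay, a 1.1-fold lower number from compound 1 to compound 4 (0.06 log units; within the scatter). At this position, then, a chain with no ring serves as well as the benzyloxy group, so the phenyl ring is not needed to hold the reading in this cell assay. Nothing available explains this result. From the compounds shown here alone, it remains open whether a longer chain, or an amine or a carboxylic acid at the chain end, would read the same. Also open, going by these compounds, is whether hexyloxy would behave alike with chloro in place of (2-(dimethylamino)ethyl)amino.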